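Trimming the acrylamide tail on a piperidine-linked pyrazole

A few compounds are considered here, and "the series" means these few. Any claim that something is new, unique, unknown or untested is made for them only; others in the source may bear on it.

Measured compounds:
- compound 1, `O=C(CCl)Nc1cccc(Cn2nc(-c3ccc(Oc4ccccc4)cc3)cc2CO)c1`: 400 nM
- compound 2, `C/C=C/C(=O)N1CCCC(n2nc(-c3ccc(Oc4ccccc4)cc3)cc2C(=O)OCC)C1`: 19100 nM
- compound 3, `C=CC(=O)Nc1cccc(Cn2nc(-c3ccc(Oc4ccccc4)cc3)cc2C(=O)OCC)c1`: 7800 nM

Three compounds share a core carrying a phenoxyphenyl group and differ in the arm that bears a reactive carbonyl. In a functional assay on Z-138 cells (Homo sapiens) for inhibition, read by luminescence and CellTiter-Glo, with a stated time of 72 h (on this read-out higher numbers stand for weaker inhibition and lower numbers for stronger inhibition), compound 1 gives 400 nM, compound 3 gives 7800 nM, and compound 2 gives 19100 nM. Compound 2 therefore stands highest of the three, meaning the weakest inhibition, and its separation from both compound 3 and compound 1 lies beyond the scatter of repeated measurements.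

Compound 4, `C=CC(=O)N1CCCC(n2nc(-c3ccc(Oc4ccccc4)cc3)cc2C(=O)OCC)C1`, has not yet been measured. It differs from compound 2 at a single place:

vinyl in place of prop-1-en-1-yl on a carbonyl carbon

The carbonyl carbon in question sits on an amide-type nitrogen in a ring, so the change trims the prop-1-en-1-yl group down to a vinyl group while leaving the rest of the molecule unchanged. Among the measured compounds shown here, no pair of measured compounds shows this exact change, so there is no measured step to lean on.

Given only that compound 2 sits at the weak end of the set, a moderate step toward stronger inhibition is expected, giving a 3.2-fold lower number from compound 2 to compound 4 (0.50 log units; beyond the scatter). Compound 4 is accordingly expected to show 6000 nM, within a range from 1500 nM to 20000 nM.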

Compound 4, half-maximal inhibitory concentration: 44000 nM
Beside the measured number, compound 4's estimate is 7.3-fold (0.87 log units) below it; measured number above the stated range.
By their numbers in this assay, from the lowest: compound 1; then compound 3; then compound 2; then compound 4.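

In this assay, replacing prop-1-en-1-yl with vinyl on the carbonyl carbon gives a 2.3-fold higher number from compound 2 to compound 4 (0.36 log units; beyond the scatter), a modest step that still lies beyond the scatter. Among the compounds shown here, this is the first direct comparison at this position, and it shows that the number responds to a change of a single carbon at the end of the arm, with the prop-1-en-1-yl compound holding the lower number of the pair, so removing that carbon does not strengthen inhibition on this 1-acylpiperidin-3-yl arm. No measurement shown here accounts for the direction of this step, so the comparison records what happens and not why.

The compounds shown leave open whether the same change would run the same way on the other arms in the set, since only this one pair isolates it. They also leave open how this carbonyl carbon would respond to other groups, such as a longer chain like but-1-en-1-yl or a prop-1-en-1-yl group ending in a dimethylamino group.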